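Adding an iodo group to compound 1

This account rests on a few compounds, and the source may have more. Where it says the series, first, only, none or still open, it means among the compounds named here.

Compound 1 `Nc1ccc(-c2nc3cc(F)ccc3s2)cc1`: 13500 nM
Compound 2 `Cc1cc(-c2nc3cccc(F)c3s2)ccc1N`: 7400 nM
Compound 3 `Cc1cc(-c2nc3ccc(F)cc3s2)ccc1N`: 10 nM

In a functional assay on OVCAR-4 cells (Homo sapiens) for inhibition (a lower number here means a stronger inhibitor of growth, a higher number a weaker inhibitor of growth), compound 1 gives 13500 nM. It sits at the weak end of this small set, level within the scatter with compound 2 at 7400 nM, while compound 3 at 10 nM lies far lower, well beyond the scatter. Compound 4 `Nc1ccc(-c2nc3cc(F)ccc3s2)cc1I` is compound 1 with iodo in place of hydrogen on an aromatic carbon, ortho to an amino group: iodo in place of hydrogen on an aromatic carbon. Among the measured compounds shown here, no measured pair isolates this kind of change. Compounds 2 and 3 each carry a methyl group ortho to an amino group, and they differ in where the fluoro sits, so that group alone does not settle the outcome: compound 2 gives 7400 nM and compound 3 gives 10 nM. A move towards stronger inhibition in this assay is expected, though its size is very uncertain. The expected change is a 45-fold lower number from compound 1 to compound 4 (1.65 log units; beyond the scatter). For compound 4 the estimated value is 300 nM, with an expected range from 15 nM to 6000 nM.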

Compound 4, concentration for 50% growth inhibition: < 10 nM
Compound 4: only a limit was reported (the forecaster's own chance of this, stated with the estimate: 10%); at least 30-fold (1.47 log units) between middle value and limit.
By their numbers in this assay, from the lowest: compound 3; then compounds 2 and 1 (each within the scatter of the next).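

In this assay, among the compounds shown here, this pair gives the first direct reading of this position: iodo in place of hydrogen on an aromatic carbon, ortho to an amino group, gives an at least 1300-fold lower number from compound 1 to compound 4 (3.13 log units; beyond the scatter) for that one change. The earlier compounds shown here could not show this, since no measured pair among them isolated a change at this place. The value of compound 4, < 10 nM, is a limit of the assay and not a number, so the step gives only a minimum size: the limit of < 10 nM in this assay, at which 1 of the 4 values shown sits.

The compounds shown leave open how far past the limit compound 4 lies, and whether chloro, bromo or a methoxy group at this place on the core of compound 1 would move the number as far. They also cannot tell whether the iodo change would carry over with the fluoro placed elsewhere on the core.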